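Removing the 2,3-dichlorophenyl group of compound 3

The source may report more compounds than this note shows. Statements on the series, on what has been measured and on what is new or still open speak of the compounds shown alone.

In a functional assay on SW-620 cells (Homo sapiens) for cytotoxicity, read by MTT assay, with a stated time of 72 h (a lower number here means a stronger inhibitor, a higher number a weaker inhibitor), compound 1 `COc1ccc(/C=C2\CCC/C(=C\c3ccccc3Cl)C2=O)cc1OC` gives 7100 nM and compound 2 `COc1cccc(/C=C2\CCC/C(=C\c3ccc(OC)c(OC)c3)C2=O)c1` gives 3700 nM in this small series. Compound 3 `COc1ccc(/C=C2\CCC/C(=C\c3cccc(Cl)c3Cl)C2=O)cc1OC` gives 10800 nM and so holds the highest of the three numbers, yet its nearest neighbour shows only a 1.5-fold higher number from compound 1 to compound 3 (0.18 log units; within the scatter) while the one clear gap is a 2.9-fold higher number from compound 2 to compound 3 (0.47 log units; beyond the scatter) in this set.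

Compound 4 `COc1cc(/C=C2\CCC/C(=C\c3ccc(OC)c(OC)c3)C2=O)ccc1O` has 4-hydroxy-3-methoxyphenyl in place of 2,3-dichlorophenyl on a double-bonded chain carbon bound to a double-bonded ring carbon. The best guide is the modest step already cited, where the same 2,3-dichlorophenyl enters in place of 3-methoxyphenyl, read here in reverse. The remaining step, a 1.9-fold lower number from compound 1 to compound 2 (0.28 log units; within the scatter) as measured, adds little. Among the measured compounds shown here, no measured compound carries the hydroxy group, so that part of the change is untested.

A modest step to a lower number is therefore expected in this assay for this change. The expected step is a 3.4-fold lower number from compound 3 to compound 4 (0.53 log units; beyond the scatter) as estimated. For compound 4 the estimate is 3200 nM with an expected range from 1100 nM to 9000 nM in this assay.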

Compound 4, half-maximal inhibitory concentration: 4500 nM
Compound 4: middle estimate off by 1.4-fold (0.15 log units), on the low side; the measured number falls inside the stated range.
By their numbers in this assay, from the lowest: compounds 2, 4, 1 and 3 (each within the scatter of the next, the first and the last beyond it).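

In this assay, the step of a 2.4-fold lower number from compound 3 to compound 4 (0.38 log units; beyond the scatter) gives a second replacement of 2,3-dichlorophenyl on this double-bonded chain carbon that lands beyond the scatter, so the earlier gap with 3-methoxyphenyl is no longer a lone case, though 2-chlorophenyl goes against any simple split, as a 1.6-fold lower number from compound 1 to compound 4 (0.20 log units; within the scatter) stays within the scatter. The hydroxy group, previously untested, now has a direct reading: a 1.2-fold higher number from compound 2 to compound 4 (0.09 log units; within the scatter) shows that this added group does not separate the two compounds in this assay at this resolution. No evidence on the origin of these steps is available.

Open, from the compounds shown here alone, is whether an amine or a carboxylic acid in place of that hydroxy would stay equally close. Also open, going by these compounds, is how an ethoxy group in place of methoxy would read here.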